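This account rests on a few compounds, and the source may have more. Where it says the series, first, only, none or still open, it means among the compounds named here.

Working notes on the series in a functional assay on HepG2 cells (Homo sapiens) for antiproliferative activity, read by colorimetric assay and MTT assay, with a stated time of 48 h; on this read-out lower numbers stand for stronger inhibition and higher numbers for weaker inhibition. Of the compounds shown here, three have numbers so far: compound 1 (`O=C(NS(=O)(=O)c1ccc(Br)cc1)c1ccncc1`) gives 6300 nM, compound 2 (`O=C(NS(=O)(=O)c1ccccc1)c1ccccn1`) gives 9900 nM and compound 3 (`O=C(NS(=O)(=O)c1ccc(F)cc1)c1ccccn1`) gives 8500 nM. Compound 3 stands within the scatter of both compound 1 and compound 2. The next compound is compound 4 (`O=C(NS(=O)(=O)c1ccc(Br)cc1)c1ccccn1`), which has bromo in place of fluoro on an aromatic carbon, para to a large group: bromo in place of fluoro on an aromatic carbon. Within the data shown here, one measured step bears on this place: a 1.2-fold lower number from compound 2 to compound 3 (0.07 log units; within the scatter), with fluoro in place of hydrogen, and it lies within the scatter. Compound 1 also carries bromo there but differs from compound 4 elsewhere in the structure, so compound 1 with 6300 nM is only indirect support. No step beyond the scatter is therefore expected in this assay. The expected change is a 1.1-fold lower number from compound 3 to compound 4 (0.05 log units; within the scatter). For compound 4 the estimated value is 7500 nM, with an expected range from 4000 nM to 14000 nM.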

Compound 4, half-maximal inhibitory concentration: 5000 nM
Compound 4: middle estimate off by 1.5-fold (0.18 log units), on the high side; measured number inside the range.
By their numbers in this assay, from the lowest: compounds 4, 1, 3 and 2 (each within the scatter of the next).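

Bromo and fluoro can now be compared directly on the aromatic carbon para to a large group: a 1.7-fold lower number from compound 3 to compound 4 (0.23 log units; within the scatter) in this assay, while bromo in place of hydrogen gives a 2.0-fold lower number from compound 2 to compound 4 (0.30 log units; within the scatter), so neither exchange at this position leaves the scatter. Among these compounds, with bromo held fixed, pyridin-2-yl in place of pyridin-4-yl on a carbonyl carbon gives a 1.3-fold lower number from compound 1 to compound 4 (0.10 log units; within the scatter), the first reading at this second place, and it too shows no separation. Nothing at hand offers an explanation for these small differences.

From the compounds shown here alone, it remains open whether an amine or a carboxylic acid on that aromatic carbon would give a step beyond the scatter. Going by these compounds, whether the pyridin-2-yl and pyridin-4-yl exchange behaves the same way with fluoro or hydrogen on that carbon also remains open.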